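The source may hold more compounds than are shown below. What is called first, only, known or untested is meant among the compounds shown, and "the series" means these compounds.

Among the measured compounds shown here, in a functional assay on HT-29 cells (Homo sapiens) for antiproliferative activity, read by MTT assay (on this read-out lower numbers stand for stronger inhibition and higher numbers for weaker inhibition), only two compounds have numbers so far. Compound 1 `CCCCC[C@@H](O)[C@H](O)/C=C/C(=O)N1CCCCC1` gives 125 ug/mL, and compound 2 `CCC[C@@H](O)[C@H](O)/C=C/C(=O)NCC(C)C` gives 181 ug/mL. For the measured compounds named here, these two values lie within the scatter of each other, so compound 1 stands level with the only other measured compound. Compound 3 `CCCCC[C@@H](O)[C@@H](O)/C=C/C(=O)N1CCCCC1` has yet to be measured in this assay. Its relation to compound 1 is the two compounds have the same atoms and bonds and differ only in configuration as drawn: 1 of 3 stereo elements differ; a stereocentre at a saturated chain carbon is drawn R in compound 1 and S in compound 3: the two compounds have the same atoms and bonds, and a stereocentre at a saturated chain carbon is drawn R in compound 1 and S in compound 3. Going by the values given here, no measured pair isolates such a change, so the data do not show its size or direction. No step beyond the scatter is therefore expected. The estimated step is a 1.0-fold higher number from compound 1 to compound 3 (0.02 log units; within the scatter), which is expected to stay within the scatter. Compound 3 is expected at 130 ug/mL, with an estimated range from 70 ug/mL to 240 ug/mL.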

Compound 3, half-maximal inhibitory concentration: "not active" (no number reported)
Compound 3 has no reported number here; no gap can be computed for the estimate.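

Among the compounds shown here, compound 3 is reported as "not active" in this assay with no number, so no step between compound 1 and compound 3 can be read. The compounds shown leave open how far the number would move with the one difference between them: the fact that compounds 1 and 3 differ only in the configuration as drawn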